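The source may report more compounds than this note shows. Statements on the series, on what has been measured and on what is new or still open speak of the compounds shown alone.

Measured so far:
compound 1, `Cc1ccccc1-c1nn(-c2ccc(C(F)(F)F)cc2)cc1CNCCN1CCN(C)CC1` — 11000 nM
compound 2, `Cc1ccccc1-c1nn(-c2ccc(F)cc2F)cc1CNC1CCN(S(C)(=O)=O)CC1` — > 20000 nM

Both compounds were tested in an ADME assay on Huh-7 cells (Homo sapiens) for cytotoxicity; a lower number here means that less compound is tolerated, a higher number that more compound is tolerated. Among the compounds with values here, compound 1 gives 11000 nM, the only actual number available. Compound 2 gives > 20000 nM, which is a limit of the assay rather than a number. The two share the same core and differ in several places at once, so no single step can be read from them; all that can be said is that compound 1 sits at a measured value while the other value rests at the limit of > 20000 nM in this assay, at which 1 of the 2 values shown sits.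

Compound 3, `Cc1ccccc1-c1nn(-c2ccc(OC(F)(F)F)cc2)cc1CNCCN1CCN(C)CC1`, has not yet been measured. It differs from compound 1 in one place only: trifluoromethoxy in place of trifluoromethyl on an aromatic carbon. Every other part of the molecule, including the chain and the ring bearing the basic nitrogens, stays as in compound 1.

Within the data shown here, with no comparable step measured, the expectation rests on compound 1 alone. The change from compound 1 to compound 3 is expected to move this assay by no more than the usual scatter, in no clear direction, so the step of a 1.1-fold higher number from compound 1 to compound 3 (0.04 log units; within the scatter) is expected to be small. Compound 3 is therefore estimated to give 12000 nM, with a range from 5000 nM to 28000 nM.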

Compound 3, half-maximal cytotoxic concentration: 17000 nM
Compound 3: the middle estimate sits 1.4-fold (0.15 log units) below what was measured; low and high end bracket the measured number.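

Within the data shown here, this is the first comparison in this assay between two compounds that differ in one place only, something the earlier pair, with its several differences, could not give. Trifluoromethoxy in place of trifluoromethyl on an aromatic carbon, para to a large group, gives a 1.5-fold higher number from compound 1 to compound 3 (0.19 log units; within the scatter), so at this position the exchange, with the oxygen it brings in, leaves no difference that can be told apart from repeat-to-repeat variation. Compound 2 remains a limit of the assay and not a number, so it cannot be set against this step: the limit of > 20000 nM in this assay, at which 1 of the 3 values shown sits.

Among these compounds, what a nitrile or a carboxylic acid at the same position would do in this assay stays open, as trifluoromethyl and trifluoromethoxy are the only two groups compared there in a single step. Among the compounds shown here, also open is whether the same exchange would give a step of similar size on a compound carrying the side chain of compound 2 in place of the one shared by compound 1 and compound 3.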